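Working notes on a short writhing-test series

The compounds below may be only part of what the source reports. "The series", "measured", "known", "first", "only" and "open" are said of these compounds alone.

Compound 1 `N#C/C(=C\c1ccc(O)c(O)c1)C(=O)SC/C=C/c1ccccc1`: 26.5%
Compound 2 `N#C/C(=C\c1ccc(O)c(O)c1)C(=O)NC/C=C/c1ccccc1`: 12.3%

Both measured compounds were run in a functional assay on the whole organism (strain CD-1) for inhibition, with Mus musculus as the target, in the writhing test, with stated times of 15 min and 20 min, at a dose of 10 mg/kg by the subcutaneous route; a higher number here means more inhibition at the dose given (going by the name of the read-out), a lower number less inhibition. In this assay compound 1 gives 26.5%, while compound 2 gives 12.3%, the lowest of the two numbers; its gap to compound 1 lies beyond the scatter, so the inhibition of compound 2 in this assay is lower than that of compound 1. For the measured compounds named here, no step between measured compounds differing in a single place is available, so the series holds no measured precedent for the change that follows.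

Compound 3 `NC/C(=C\c1ccc(O)c(O)c1)C(=O)NC/C=C/c1ccccc1` differs from compound 2 in one place: aminomethyl in place of cyano on a double-bonded chain carbon bound to a carbonyl carbon and a double-bonded chain carbon. Going by the values given here, with no comparable step measured, nothing in the data points to a gain or a loss of a set size; the working assumption is a step in this assay that stays within the scatter, in either direction. On that basis compound 3 is expected to give 10% in this assay, with a range of 0% to 25%. The step this estimate implies, a number 2.3 percentage points lower from compound 2 to compound 3 (within the scatter), is expected to be small.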

Compound 3, a percentage reported as inhibition, in the whole organism at one dose (the size of the read-out at that dose, not a potency): 50%
For compound 3 the middle estimate is 40 percentage points below the measured one; the whole stated range lies below it.
By their numbers in this assay, from the lowest: compound 2; then compound 1; then compound 3.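

In this assay, aminomethyl in place of cyano on a double-bonded chain carbon bound to a carbonyl carbon and a double-bonded chain carbon goes with a number 37.7 percentage points higher from compound 2 to compound 3 (beyond the scatter). This position is therefore not indifferent to its group: the two groups have the same heavy-atom count, carbon and nitrogen alike, yet the exchange moves the read-out well past the scatter. Nothing measured here accounts for the step.

The compounds shown leave open whether hydroxymethyl, aminoethyl or a carboxylic acid at this position would match aminomethyl in this assay, and whether dimethylaminomethyl would keep the gain. They also leave open whether the same exchange on compound 1 would bring a step of similar size.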